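This account rests on a few compounds, and the source may have more. Where it says the series, first, only, none or still open, it means among the compounds named here.

Within the data shown here, compound 2, `CCCCC[Se]c1nc(NCc2ccccc2)c2ccccc2n1`, gives the only number in this set: in a functional assay on MCF7 cells (Homo sapiens) for cytotoxicity, read by MTT assay, with a stated time of 72 h (on this read-out higher numbers stand for weaker inhibition of growth and lower numbers for stronger inhibition of growth), compound 2 gives 47100 nM. Compound 1, `C[Se]c1nc(N)c2ccccc2n1`, reaches only a limit, and in this assay compound 1 gives > 100000 nM. Compound 3, `CCCCC[Se]c1nc(N)c2ccccc2n1`, differs from compound 2 by hydrogen in place of benzyl on a nitrogen on an aromatic ring. With compound 1 sitting at the limit of > 100000 nM in this assay, at which 1 of the 2 values shown sits, the step is expected to run toward weaker inhibition of growth, a 2.5-fold higher number from compound 2 to compound 3 (0.41 log units; beyond the scatter), and to be larger than the ordinary scatter. Compound 3 is therefore estimated in this assay at 120000 nM, within a range from 40000 nM to 300000 nM, with a real chance that only a limit is reported.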

Compound 3, concentration for total growth inhibition: 59500 nM
For compound 3 the middle estimate is 2.0-fold (0.30 log units) above the measured one, within the range that was stated.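

Hydrogen in place of benzyl on this nitrogen on an aromatic ring gives a 1.3-fold higher number from compound 2 to compound 3 (0.10 log units; within the scatter) in this assay and so leaves the two compounds indistinguishable, which the earlier compounds could not show. Butyl in place of hydrogen on the saturated chain carbon bound to a selenium atom gives an at least 1.6-fold lower number from compound 1 to compound 3 (0.22 log units; that floor lies within the scatter) and can be read only as a floor, because compound 1 is held at a limit: the limit of > 100000 nM in this assay, at which 1 of the 3 values shown sits. Going by these compounds, whether a longer chain at that carbon, or a phenethyl or acetyl group on the nitrogen, would move the number beyond the scatter remains open.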